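The source may hold more compounds than are shown below. What is called first, only, known or untested is meant among the compounds shown, and "the series" means these compounds.

Measured so far in a functional assay on the whole organism for inhibition, with Mus musculus as the target, with stated times of 3 days and 30 min, at a dose of 30 mg/kg by the oral route; a higher number here means more inhibition at the dose given (going by the name of the read-out), a lower number less inhibition:

compound 1 `Cc1ccc(-c2cc(C)n(S(=O)(=O)Oc3ccccc3)n2)cc1`, giving 15.2%
compound 2 `Cc1cc(-c2cccc(Cl)c2)nn1S(=O)(=O)Oc1ccccc1`, giving 10%

Going by the values given here, compound 2 has the lower of the two numbers, its only neighbour being compound 1; the step of a number 5.2 percentage points lower from compound 1 to compound 2 (within the scatter) is within the scatter, so the two values cannot be ranked.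

The next compound is compound 3 `Cc1cc(-c2ccco2)nn1S(=O)(=O)Oc1ccccc1`. Relative to compound 2 the change is furan-2-yl in place of 3-chlorophenyl on an aromatic carbon.

Among the compounds with values here, no measured step bears on this change: the single step on record, a number 5.2 percentage points lower from compound 1 to compound 2 (within the scatter), exchanges one six-membered aromatic ring of carbon only for another and was itself within the scatter. Within the data shown here, a five-membered ring with one oxygen entering in place of the chlorophenyl has no counterpart among the measured compounds. With nothing to anchor a direction, the expectation is a step of a number 2 percentage points higher from compound 2 to compound 3 (within the scatter) of no size beyond the scatter. For compound 3 the estimate is therefore 12%, with a range from 0% to 28%.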

Compound 3, a percentage reported as inhibition, in the whole organism at one dose (the size of the read-out at that dose, not a potency): 12.5%
The estimate for compound 3 lay 0.5 percentage points below the measured number; the measured number falls inside the stated range.
By their numbers in this assay, from the lowest: compounds 2, 3 and 1 (each within the scatter of the next).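

In this assay, this aromatic carbon next to the ring nitrogen now carries a five-membered aromatic ring with 1 hetero atom as well as six-membered aromatic rings of carbon only. Furan-2-yl in place of 3-chlorophenyl gives a number 2.5 percentage points higher from compound 2 to compound 3 (within the scatter), and furan-2-yl in place of 4-methylphenyl gives a number 2.7 percentage points lower from compound 1 to compound 3 (within the scatter). Neither exchange moves the read-out beyond the scatter, so these three aromatic groups cannot be ranked at this position, and nothing available offers an explanation for the values.

Open, as far as these compounds go, is whether a non-aromatic group at this carbon, such as a morpholine or a longer alkyl chain, would give a step beyond the scatter in this assay. Also open, from the compounds shown here alone, is what a carboxylic acid would do in place of the methyl group two ring bonds from this carbon.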